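A few compounds are considered here, and "the series" means these few. Any claim that something is new, unique, unknown or untested is made for them only; others in the source may bear on it.

Measured in a functional assay on MDA-MB-435 cells (Homo sapiens) for cytotoxicity, read by MTT assay, with a stated time of 72 h; on this read-out lower numbers stand for stronger inhibition and higher numbers for weaker inhibition:
compound 1 `COc1cccc(CNC(=O)c2nc(Br)c3cccnc3c2N[C@H]2CC[C@H](N)CC2)c1` gives 7000 nM;
compound 2 `C[C@@H](CO)Nc1nc(C(=O)NCc2ccc(F)cc2)c(O)c2ncccc12` gives > 20000 nM;
compound 3 `N[C@H]1CC[C@H](Nc2c(C(=O)NCc3ccc(Cl)cc3)nc(Br)c3cccnc23)CC1` gives 1000 nM.

The value for compound 2 is a limit of the assay and not a number. Among the two numbers, compound 3 has the lowest; its nearest neighbour is compound 1, and the step of a 7.0-fold lower number from compound 1 to compound 3 (0.85 log units; beyond the scatter) is the only single-point change recorded, brought by 4-chlorophenyl in place of 3-methoxyphenyl on the saturated chain carbon bound to the amide-type nitrogen.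

Compound 4 `N[C@H]1CC[C@H](Nc2c(C(=O)NCc3ccc(Oc4ccccc4)cc3)nc(Br)c3cccnc23)CC1` differs from compound 3 by phenoxy in place of chloro on an aromatic carbon. Among the measured compounds shown here, the one measured step touches the same aryl ring, but swaps two different groups, so it gives only a loose guide; it shows that the aryl substituent can move this assay by a modest amount. Without a closer comparison, the expectation for compound 4 is a step of a 1.5-fold higher number from compound 3 to compound 4 (0.18 log units; within the scatter) of no clear direction beyond the scatter, and its value in this assay is estimated at 1500 nM, with a range from 300 nM to 8000 nM.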

Compound 4, half-maximal inhibitory concentration: 4000 nM
Compound 4: the middle estimate sits 2.7-fold (0.43 log units) below what was measured; the measured number falls inside the stated range.
By their numbers in this assay, from the lowest: compound 3; then compounds 4 and 1 (each within the scatter of the next). At a limit, above all of these: compound 2.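

In this assay, the step of a 4.0-fold higher number from compound 3 to compound 4 (0.60 log units; beyond the scatter) isolates this aromatic carbon, para to a large group, as a place that moves the number by itself, since only the group on it differs. The earlier step had changed both the group and where it sat on the ring, so it could not show this. Even with phenoxy, which brings seven heavy atoms and a second aromatic ring in place of a single chlorine, compound 4 gives a number, 4000 nM, and not a limit. Nothing measured here gives a reason for this step.

From the compounds shown here alone, whether the step follows the added ring or the oxygen that links it stays open, and a benzyl or cyclohexyl group on this carbon would bear on that. Going by these compounds, how a nitrile or an amine would read at this carbon also remains unknown.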